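A Further Hydroxy on Compound 2

The source may report more compounds than this note shows. Statements on the series, on what has been measured and on what is new or still open speak of the compounds shown alone.

Compound 1 `O=C(/C=C/c1ccc(O)c(O)c1)CC(=O)/C=C/c1cccc(O)c1O`: 3800 nM
Compound 2 `O=C(/C=C/c1ccc(O)c(O)c1)/C=C/c1ccccc1O`: 111000 nM
Compound 3 `O=C(/C=C/c1ccc(O)cc1)/C=C/c1ccc(O)c(O)c1`: 19000 nM

In a physicochemical assay for solubility, using the shake flask method, with a stated time of 12 h (a higher number here means a more soluble compound, a lower number a less soluble compound), compound 2 gives the highest number of the three. Compound 4 `O=C(/C=C/c1ccc(O)c(O)c1)/C=C/c1cc(O)ccc1O` departs from it by one change: hydroxy in place of hydrogen on an aromatic carbon. Going by the values given here, no measured pair shows this change. Among the compounds with values here, the only measured step is a 5.8-fold lower number from compound 2 to compound 3 (0.77 log units; beyond the scatter), a modest one that swaps 2-hydroxyphenyl for 4-hydroxyphenyl, so it bears on the new change only loosely. With compound 2 at the top of the series, a step of about that size, downward, is expected, with little certainty. The expected change is a 2.2-fold lower number from compound 2 to compound 4 (0.35 log units; beyond the scatter). For compound 4 the estimated value is 50000 nM, with an expected range of 12000 nM to 200000 nM.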

Compound 4, solubility: 123000 nM
Estimate against measurement, compound 4: 2.5-fold (0.39 log units) below; the measured number falls inside the stated range.
By their numbers in this assay, from the lowest: compound 1; then compound 3; then compounds 2 and 4 (each within the scatter of the next).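

In this assay, hydroxy in place of hydrogen on an aromatic carbon, meta to a large group and para to a hydroxy group, gives a 1.1-fold higher number from compound 2 to compound 4 (0.04 log units; within the scatter). Going by these compounds alone, this is the first measured pair to show this change, and at this position its step stays within the scatter, unlike the step already measured between compound 2 and compound 3. Nothing measured here explains the result. Going by these compounds, whether an amine or a methoxy group at the same position would read alike remains open, as does hydroxy on another aromatic carbon of that ring.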